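A few compounds are considered here, and "the series" means these few. Any claim that something is new, unique, unknown or untested is made for them only; others in the source may bear on it.

Three compounds share one core and carry an aryl group on a carbon with a double bond to nitrogen. Compound 1 `COc1ccc2cc(C(C)c3nnc4n3N=C(c3ccc(Br)cc3)CS4)ccc2c1` gives 11500 nM in a functional assay on MCF7 cells (Homo sapiens) for inhibition, read by sulforhodamine B assay, with a stated time of 72 h; on this read-out higher numbers stand for weaker inhibition and lower numbers for stronger inhibition. Compound 2 `COc1ccc2cc(C(C)c3nnc4n3N=C(c3ccc(Cl)cc3Cl)CS4)ccc2c1` gives 14600 nM in this assay. Compound 3 `CC(C)Cc1ccc(C(C)c2nnc3n2N=C(c2ccc(Cl)cc2Cl)CS3)cc1` gives 11800 nM in this assay. Compound 1 differs from compound 2 by 4-bromophenyl in place of 2,4-dichlorophenyl on a carbon with a double bond to nitrogen and the step is a 1.3-fold lower number from compound 2 to compound 1 (0.10 log units; within the scatter). The difference between the cores of compound 2 and compound 3 is not broken down here; their values lie within the scatter of each other. Compound 4 `CC(C)Cc1ccc(C(C)c2nnc3n2N=C(c2ccc(Br)cc2)CS3)cc1` is not yet measured. It differs from compound 3 by 4-bromophenyl in place of 2,4-dichlorophenyl on a carbon with a double bond to nitrogen, the same change as from compound 2 to compound 1, at a place described in the same words. The step is expected to be a 1.3-fold lower number from compound 3 to compound 4 (0.12 log units; within the scatter), resting on the step of a 1.3-fold lower number from compound 2 to compound 1 (0.10 log units; within the scatter) in the matched pair. Compound 4 is estimated at 9000 nM, within a range of 4500 nM to 18000 nM.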

Compound 4, half-maximal inhibitory concentration: 9400 nM
The estimate for compound 4 lay 1.0-fold (0.02 log units) below the measured number, and the stated range covers the measured number.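

In this assay, 4-bromophenyl in place of 2,4-dichlorophenyl gives a 1.3-fold lower number from compound 3 to compound 4 (0.10 log units; within the scatter), and this step agrees with the one on the other core: the same change on two cores in this assay, a 1.3-fold lower number (0.10 log units; within the scatter) from compound 2 to compound 1 and a 1.3-fold lower number (0.10 log units; within the scatter) from compound 3 to compound 4, 1.0-fold (0.00 log units) apart, within the scatter of two such steps

The change therefore carries across these two cores with no visible difference in step size. Both steps lie within the scatter, however, so this agreement does not show a real effect of the change on either core, and two cores say nothing about others in the series.

Still open, as far as these compounds go, is whether a group such as an amine or a carboxylic acid, in place of the 4-bromophenyl on the carbon with a double bond to nitrogen, would give a step beyond the scatter. From the compounds shown here alone, whether the step holds on any other read-out also remains open.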